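Amino Substitution on a Fused Core: Two Pairs Compared

The compounds below may be only part of what the source reports. "The series", "measured", "known", "first", "only" and "open" are said of these compounds alone.

Measured compounds:
- Compound 1, `ClCc1ccc(Cn2cnc3c(Cl)ncnc32)cc1`, 3460 nM
- Compound 2, `Nc1nc(Cl)c2ncn(Cc3ccc(CCl)cc3)c2n1`, 27500 nM
- Compound 3, `ClCc1ccccc1Cn1cnc2c(Cl)ncnc21`, 23400 nM

The three measured compounds were tested in a functional assay on SF-295 cells (Homo sapiens) for cytotoxicity, read by sulforhodamine B assay, with a stated time of 48 h; on this read-out lower numbers stand for stronger inhibition of growth and higher numbers for weaker inhibition of growth. Compound 1 gives 3460 nM, the lowest of the three numbers. Compound 2 differs from compound 1 by one change, (amino in place of hydrogen on an aromatic carbon), and in this assay compound 2 gives 27500 nM; the step is a 7.9-fold higher number from compound 1 to compound 2 (0.90 log units; beyond the scatter). Compound 3 shares its atoms with compound 1 but joins them differently; the difference between the two cores is not broken down here. In this assay compound 3 gives 23400 nM, a number close to that of compound 2 and well apart from that of compound 1.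

Compound 4, `Nc1nc(Cl)c2ncn(Cc3ccccc3CCl)c2n1`, has not yet been measured. It stands to compound 3 as compound 2 stands to compound 1: the change is amino in place of hydrogen on an aromatic carbon, and the surroundings of the place are described in the same words for both pairs, so this is the same change made on a different core. Among the measured compounds shown here, the only measured example of this change, from compound 1 to compound 2, produced a higher number, so a higher number is expected here too. For the measured compounds named here, because a 7.9-fold higher number from compound 1 to compound 2 (0.90 log units; beyond the scatter) is the only guide, the step expected is a 6.4-fold higher number from compound 3 to compound 4 (0.81 log units; beyond the scatter), with wide uncertainty since the core differs. For compound 4 in this assay the estimate is 150000 nM, expected to fall between 45000 nM and 450000 nM.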

Compound 4, concentration for total growth inhibition: 23400 nM
For compound 4 the middle estimate is 6.4-fold (0.81 log units) above the measured one, and the stated range ends above it.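

In this assay, putting amino in place of hydrogen on an aromatic carbon gives no change at the digits printed from compound 3 to compound 4 (within the scatter), so on this core the swap leaves the reading where it was. Set beside the earlier step, this shows that the size of the step did not carry over from one core to the other, and that a step read on one of these cores is a poor guide to the same step on the other: the same change on two cores in this assay, a 7.9-fold higher number (0.90 log units; beyond the scatter) from compound 1 to compound 2 and no change at the digits printed (within the scatter) from compound 3 to compound 4, 7.9-fold (0.90 log units) apart, beyond the scatter of two such steps. Among the compounds shown here, it does not show why the two cores part ways, and with only two pairs, both read only in this assay, it cannot say which of the two steps would be the more usual one across the series.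

The compounds shown leave open whether a different group in the same place, such as a hydroxyl or a methoxy group, would follow the pattern of amino on either core. They also leave open how the amino change would behave on any third core, so the split seen here rests on these four compounds alone.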